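Aryl swap on the ring nitrogen of the fused core

The compounds below may be only part of what the source reports. "The series", "measured", "known", "first", "only" and "open" are said of these compounds alone.

Measured so far in a functional assay on A549 cells (Homo sapiens) for cytotoxicity, read by MTT assay, with a stated time of 72 h; a higher number here means a weaker inhibitor, a lower number a stronger inhibitor:
compound 1 `Cn1c(=O)c(C(=O)Nc2ccc(Oc3ccncc3-c3cccnc3)c(F)c2)nn(-c2ccccc2F)c1=O` — 610 nM
compound 2 `COc1ccc(-n2nc(C(=O)Nc3ccc(Oc4ccncc4-c4cccnc4)c(F)c3)c(=O)n(C)c2=O)c(OC)c1` — 890 nM
compound 3 `O=C(Nc1ccc(Oc2ccncc2-c2cccnc2)c(F)c1)c1nn(-c2cccc(F)c2)c(=O)c2ccccc12` — 1750 nM

Compound 3 carries a fused core that compounds 1 and 2 do not share. Against compound 1 it sits beyond the scatter, on the weaker side; against compound 2 the two numbers lie within the scatter of each other, so no order between them can be read.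

Compound 4 `O=C(Nc1ccc(Oc2ccncc2-c2cccnc2)c(F)c1)c1nn(-c2ccc(Cl)cc2)c(=O)c2ccccc12` is the next member. It differs from compound 3 in one place: 4-chlorophenyl in place of 3-fluorophenyl on an aromatic nitrogen. For the measured compounds named here, the only measured step of the same kind, an aryl exchange on a ring nitrogen of the core, is the one from compound 1 to compound 2, a 1.5-fold higher number from compound 1 to compound 2 (0.16 log units; within the scatter), though it was made on the other core. That step stayed within the scatter, and nothing in the data shown points to the fused core reacting differently to such an exchange. The expectation for compound 4 is therefore a step of a 1.0-fold lower number from compound 3 to compound 4 (0.01 log units; within the scatter) in this assay, with no direction claimed beyond the scatter.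

Compound 4 is estimated at 1700 nM in this assay, expected within 700 nM to 4200 nM.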

Compound 4, half-maximal inhibitory concentration: 1020 nM
Compound 4: middle estimate off by 1.7-fold (0.22 log units), on the high side; measured number inside the range.
By their numbers in this assay, from the lowest: compounds 1, 2, 4 and 3 (each within the scatter of the next, the first and the last beyond it).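

On the fused core, the aryl group on the ring nitrogen now has a measured exchange of its own. In this assay the swap of 3-fluorophenyl for 4-chlorophenyl gives a step (a 1.7-fold lower number from compound 3 to compound 4 (0.23 log units; within the scatter)) that stays within the scatter, so no order between these two aryl groups can be read. With the exchange on the other core (a 1.5-fold higher number from compound 1 to compound 2 (0.16 log units; within the scatter)), both aryl exchanges at a ring nitrogen shown so far stay within the scatter, and neither pair goes against this, although two exchanges on two different cores make only a narrow pattern. No measurement is at hand that bears on the reason for these numbers.

All four aryl groups shown are phenyl rings carrying fluorine, chlorine or methoxy groups, so it remains open whether a phenyl ring bearing an amine or a carboxylic acid, or a longer alkyl chain in place of the aryl ring, would move the number beyond the scatter. On these data alone, no aryl group appears on both cores, so the effect of the core itself, with the aryl group held the same, also remains open.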